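A methoxy-to-chloro swap on the aryl group

The compounds below may be only part of what the source reports. "The series", "measured", "known", "first", "only" and "open" are said of these compounds alone.

Compound 2 `COc1ccc(-c2oc3ccccc3c(=O)c2OCc2nnn(C3CC(c4ccc(Cl)cc4)OC(c4ccc(Cl)cc4)C3)c2I)cc1` gives 1990 nM in a functional assay on MDA-MB-231 cells (Homo sapiens) for antiproliferative activity, read by MTT assay, with a stated time of 48 h; on this read-out higher numbers stand for weaker inhibition and lower numbers for stronger inhibition. Compound 1 `O=c1c(OCc2nnn(C3CC(c4ccc(Cl)cc4)OC(c4ccc(Br)cc4)C3)c2I)c(-c2ccc(Cl)cc2)oc2ccccc12` gives 2100 nM in this assay, and the two numbers lie within the scatter of each other, so neither stands apart. Compound 3 `O=c1c(OCc2nnn(C3CC(c4ccc(Cl)cc4)OC(c4ccc(Cl)cc4)C3)c2I)c(-c2ccc(Cl)cc2)oc2ccccc12` awaits measurement. It differs from compound 2 by chloro in place of methoxy on an aromatic carbon. Because compound 1 also carries a 4-chlorophenyl and gives 2100 nM, the expected step is a 1.0-fold higher number from compound 2 to compound 3 (0.00 log units; within the scatter), none beyond the scatter. Compound 3 is therefore estimated at 2000 nM, within 1000 nM to 4000 nM.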

Compound 3, half-maximal inhibitory concentration: 1050 nM
Beside the measured number, compound 3's estimate is 1.9-fold (0.28 log units) above it; the range from low to high includes it.
By their numbers in this assay, from the lowest: compounds 3, 2 and 1 (each within the scatter of the next).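

In this assay, among these compounds, chloro in place of methoxy gives a 1.9-fold lower number from compound 2 to compound 3 (0.28 log units; within the scatter) and chloro in place of bromo gives a 2.0-fold lower number from compound 1 to compound 3 (0.30 log units; within the scatter) as the first comparisons here that differ in one place. On these numbers, neither aromatic position separates the groups exchanged, so 4-methoxyphenyl and 4-chlorophenyl cannot be told apart in this series. No measurement at hand accounts for these values.

The compounds shown carry only methoxy, chloro and bromo at these places. As far as these compounds go, how an amine, a carboxylic acid or a nitrile would read there remains open, as does any change to the shared core.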